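Dropping one methyl from compound 3

The source may hold more compounds than are shown below. What is called first, only, known or untested is meant among the compounds shown, and "the series" means these compounds.

In a functional assay on MDA-MB-435 cells (Homo sapiens) (on this read-out higher numbers stand for weaker inhibition of growth and lower numbers for stronger inhibition of growth), compound 3 `COc1ccc(-c2cc(O)c3c(C)cc(C)nc3n2)cc1` gives 28800 nM and lies within the scatter of compound 2 `COc1ccc(-c2cc(O)c3cccnc3n2)cc1` at 20000 nM while compound 1 `Cc1cc(C)c2c(O)cc(-c3ccc(Cl)cc3)nc2n1` stands apart at 4070 nM on this read-out. Compound 4 `COc1ccc(-c2cc(O)c3ccc(C)nc3n2)cc1` has hydrogen in place of methyl on an aromatic carbon, opposite the ring nitrogen (hydrogen in place of methyl on an aromatic carbon). Going by the values given here, the one measured step of a 7.1-fold higher number from compound 1 to compound 3 (0.85 log units; beyond the scatter) concerns methoxy in place of chloro and does not touch this methyl. With compound 2 at 20000 nM and compound 3 at 28800 nM so close, no change beyond the scatter is expected in this assay here. The expected step of a 1.2-fold lower number from compound 3 to compound 4 (0.08 log units; within the scatter) is therefore small. For compound 4 the estimated value is 24000 nM with an expected range of 11000 nM to 50000 nM on this reasoning.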

Compound 4, concentration for 50% growth inhibition: 42700 nM
Beside the measured number, compound 4's estimate is 1.8-fold (0.25 log units) below it, within the range that was stated.
By their numbers in this assay, from the lowest: compound 1; then compounds 2, 3 and 4 (each within the scatter of the next, the first and the last beyond it).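

In this assay, taking off the methyl opposite the ring nitrogen gives a 1.5-fold higher number from compound 3 to compound 4 (0.17 log units; within the scatter) and so leaves no readable effect of this methyl on its own. Going by these compounds alone, the other methyl is read through a 2.1-fold higher number from compound 2 to compound 4 (0.33 log units; beyond the scatter) as a modest step just beyond the scatter, the only methyl change here that clears it. No evidence on hand bears on these steps.

Still open, as far as these compounds go, is whether an amine, a carboxylic acid or a longer chain opposite the ring nitrogen would move the number. Also open, from the compounds shown here alone, is whether hydrogen at this position would read the same with chloro in place of methoxy.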